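This account rests on a few compounds, and the source may have more. Where it says the series, first, only, none or still open, it means among the compounds named here.

Among the compounds with values here, in an ADME assay on HEK293 cells (Homo sapiens) for cytotoxicity, read by reporter gene assay and resazurin assay, with a stated time of 48 h (a higher number here means that more compound is tolerated, a lower number that less compound is tolerated), compound 3 `O=C(Nc1cccc(Cl)c1)c1cc(Br)cc(Br)c1` gives 53000 nM, the highest of the two actual numbers so far, while compound 1 `O=C(Nc1cccc(Cl)c1)c1cc(Br)cc(Br)c1O` gives 18000 nM. Compound 2 `O=C(Nc1ccccc1)c1cccc(Br)c1` reads > 100000 nM, which is a limit of the assay and not a number. Compound 4 `O=C(Nc1cccc(Cl)c1)c1cccc(Br)c1` differs from compound 3 by hydrogen in place of bromo on an aromatic carbon. Within the data shown here, no measured step makes this exact change. The closest guide is another removal of a group from an aromatic carbon, hydrogen in place of hydroxy, which gave a 2.9-fold higher number from compound 1 to compound 3 (0.47 log units; beyond the scatter). The expected step is a 1.7-fold higher number from compound 3 to compound 4 (0.23 log units; within the scatter), in the same upward direction but no larger. Such a reading may also run into (the limit of > 100000 nM in this assay, at which 1 of the 3 values shown sits). For compound 4 the estimate is 90000 nM, with an expected range from 40000 nM to 200000 nM.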

Compound 4, half-maximal cytotoxic concentration: 51000 nM
Compound 4: middle estimate off by 1.8-fold (0.25 log units), on the high side; the range from low to high includes it.
By their numbers in this assay, from the lowest: compound 1; then compounds 4 and 3 (each within the scatter of the next). At a limit, above all of these: compound 2.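

Replacing this bromo with hydrogen gives a 1.0-fold lower number from compound 3 to compound 4 (0.02 log units; within the scatter), so unlike the hydroxy removed earlier, this bromo leaves no readable mark on how much compound is tolerated. Replacing hydrogen with chloro gives an at least 1.9-fold lower number from compound 2 to compound 4 (0.29 log units; that floor lies within the scatter). Compound 2 stands at a limit, not a number, so that step gives only a floor: the limit of > 100000 nM in this assay, at which 1 of the 4 values shown sits.

As far as these compounds go, whether an amine or a carboxylic acid at this position would shift the tolerated concentration remains open. So does whether replacing the remaining bromo would matter.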